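Cytotoxicity notes: pyrimidinyl for pyrazolyl on the fused core

The source may report more compounds than this note shows. Statements on the series, on what has been measured and on what is new or still open speak of the compounds shown alone.

Of the compounds shown here, three have been read in an ADME assay on HeLa cells (Homo sapiens) for cytotoxicity, read by ATP content, with a stated time of 3 days; a higher number here means that more compound is tolerated, a lower number that less compound is tolerated. Compound 1 `CS(=O)(=O)CCCn1c(Cn2c(=O)n(C3CN(S(C)(=O)=O)C3)c3ccncc32)cc2cc(Cl)ccc21` gives > 50000 nM, which is a limit of the assay and not a number. Compound 2 `COc1ccc(-n2c(=O)n(Cc3cc4cc(Cl)ccc4n3CCCC#N)c3cnccc32)cc1OC` gives > 50000 nM, again a limit. Compound 3 `Cn1ccc(-n2c(=O)n(Cc3cc4cc(Cl)ccc4n3CCCC#N)c3cnccc32)n1` gives > 50000 nM, also a limit. Among the measured compounds shown here, the only single-point change among them, from compound 2 to compound 3, is a step that the two limits leave unreadable from compound 2 to compound 3; with both ends at the limit its size cannot be read. Compound 3 therefore stands at the top of the measurable range, together with the two others, and this is the whole evidence at hand: the limit of > 50000 nM in this assay, at which 3 of the 3 values shown sit.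

Compound 4 `N#CCCCn1c(Cn2c(=O)n(-c3ncccn3)c3ccncc32)cc2cc(Cl)ccc21` differs from compound 3 by pyrimidin-2-yl in place of 1-methyl-1H-pyrazol-3-yl on an aromatic nitrogen. For the measured compounds named here, no measured step touches this pair, and the one step that exists in this assay is unreadable, so no direction or size can be derived from the numbers. Given that every value so far sits at the limit, the step is expected to be a step that the limit leaves unreadable from compound 3 to compound 4, nothing beyond the scatter. Compound 4 is accordingly estimated at 70000 nM, within 30000 nM to 200000 nM, most likely reported again as a limit.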

Compound 4, half-maximal cytotoxic concentration: > 50000 nM
Compound 4 was reported as a limit; the forecaster's own chance of this, stated with the estimate: 85%; the middle value lies beyond the limit too.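

In this assay compound 4 gives > 50000 nM, again a limit of the assay and not a number. The steps from compound 2 and compound 3 to compound 4 cannot be read, with both ends of each at a limit. The compounds shown leave open at what concentration any of them becomes cytotoxic, and whether pyrimidin-2-yl, 1-methyl-1H-pyrazol-3-yl and 3,4-dimethoxyphenyl differ at all.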